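The compounds below may be only part of what the source reports. "The series", "measured", "known", "first", "only" and "open" are said of these compounds alone.

Compound 2, `CCOCCC1([C@H](O)/C=C/[C@H]2COC(=O)N2CCSc2nc(C(=O)O)cs2)CCC1`, gives 745 nM in an assay on isolated protein for agonist activity at prostaglandin E2 receptor EP4 subtype (Homo sapiens) (a higher number here means that more compound is needed for the effect, a lower number that less compound is needed), the highest of the three numbers measured. Compound 1, `CCCCC(C)(C)[C@H](O)/C=C/[C@H]1CCC(=O)N1CCSc1nc(C(=O)O)cs1`, gives 4.2 nM, a gap from compound 2 that is beyond the scatter, and compound 3, `CCCC[C@H](C)C[C@H](O)/C=C/[C@H]1CCC(=O)N1CCSc1nc(C(=O)O)cs1`, gives 3 nM, a gap from compound 2 that is likewise beyond the scatter. For the measured compounds named here, the one measured step, a 1.4-fold lower number from compound 1 to compound 3 (0.15 log units; within the scatter), changes the side chain at the carbinol carbon and stays within the scatter; it does not address the ethoxy group of compound 2.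

Compound 4, `O=C(O)c1csc(SCCN2C(=O)OC[C@@H]2/C=C/[C@@H](O)C2(CCc3ccccc3)CCC2)n1`, differs from compound 2 by phenyl in place of ethoxy on a saturated chain carbon, two bonds along the chain from a saturated ring carbon. Going by the values given here, no measured pair shows the effect of this exchange, and the two compounds that share the pyrrolidinone-free core with compound 2 are absent. Among the compounds with values here, the three numbers offer no direction for the step, so the expectation rests on the weak starting point alone: a change away from the ethoxy group is as likely to lower as to raise the number, and no large shift beyond the scatter is predicted with confidence. Compound 4 is therefore expected to give 400 nM, between 60 nM and 2500 nM, a step of a 1.9-fold lower number from compound 2 to compound 4 (0.27 log units; within the scatter) that is estimated rather than known.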

Compound 4, half-maximal effective concentration: 465 nM
Estimate against measurement, compound 4: 1.2-fold (0.07 log units) below; low and high end bracket the measured number.
By their numbers in this assay, from the lowest: compounds 3 and 1 (each within the scatter of the next); then compounds 4 and 2 (each within the scatter of the next).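

In this assay, phenyl in place of ethoxy on a saturated chain carbon, two bonds along the chain from a saturated ring carbon, gives a 1.6-fold lower number from compound 2 to compound 4 (0.20 log units; within the scatter), so the two groups cannot be told apart at this position. The earlier compounds shown here offered no step at this place; this one shows that the ethoxy group, with its hydrogen-bond acceptor, and a six-membered aromatic ring of carbon only, with no such acceptor, can stand here and leave the number within the scatter. The oxygen of the ethoxy group is therefore not shown to matter for this read-out on this core, though a single pair can say no more than that, and nothing at hand explains the result.

Going by these compounds, what an amine, a hydroxyl or a pyridine ring would do at the same place stays open, as does the effect of a substituent such as fluorine on the phenyl ring. On these data alone, it is also open whether the same exchange would read alike on the core of compound 1 or compound 3, where the numbers start much lower.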